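The compounds below may be only part of what the source reports. "The series", "measured", "known", "first", "only" and "open" are said of these compounds alone.

Measured so far in a functional assay on the whole organism for positive allosteric modulation, with Mus musculus as the target; on this read-out lower numbers stand for an effect already at smaller amounts and higher numbers for an effect only at larger amounts of compound:
- compound 1 `CCC(=O)N(c1ccc(Br)cc1)C1CCCC1N(C)C`: 2 mg/kg
- compound 2 `CCC(=O)N(c1ccc(C(F)(F)F)cc1)C1CCCC1N(C)C`: 10 mg/kg

Among the compounds with values here, of these two compounds, compound 2 stands at the higher number, 10 mg/kg, and compound 1 is its only neighbour. The next compound, compound 3 `CCC(=O)N(c1ccc(C#N)cc1)C1CCCC1N(C)C`, keeps the core of compound 2 and carries cyano in place of trifluoromethyl on an aromatic carbon. Within the data shown here, no measurement yet covers a cyano group.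

Among the measured compounds shown here, the only measured step that bears on this change is a 5.0-fold higher number from compound 1 to compound 2 (0.70 log units; beyond the scatter). It is modest but beyond the scatter, and it shows that replacing one group at this place with another can move the number in this assay. That single step involves a different pair of groups, so it gives no firm direction for the cyano swap. It does suggest how wide the range should be. The expected change is therefore small and within the scatter, leaning slightly upward, as the estimated 1.2-fold higher number from compound 2 to compound 3 (0.08 log units; within the scatter) shows. For compound 3 the expected value is 12 mg/kg, with an estimated range from 4 mg/kg to 40 mg/kg.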

Compound 3, dose for half-maximal effect: 10 mg/kg
For compound 3 the middle estimate is 1.2-fold (0.08 log units) above the measured one, within the range that was stated.
By their numbers in this assay, from the lowest: compound 1; then compounds 2 and 3 (each within the scatter of the next).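

In this assay, the step of no change at the digits printed from compound 2 to compound 3 (within the scatter) shows that this position, para to a large group, does not distinguish cyano from trifluoromethyl, even though cyano has 2 heavy atoms against 4 and brings 1 hydrogen-bond acceptor where trifluoromethyl has none. The step of a 5.0-fold higher number from compound 1 to compound 3 (0.70 log units; beyond the scatter) matches the step of a 5.0-fold higher number from compound 1 to compound 2 (0.70 log units; beyond the scatter), so bromo is now set apart from two different groups at this place, not just from trifluoromethyl. No available evidence accounts for the separation of bromo from the other two groups or for the lack of separation between cyano and trifluoromethyl.

Going by these compounds, it remains open whether chloro, methoxy or a plain hydrogen at this place would stand with compound 1 or with compounds 2 and 3, and so whether the lower number belongs to bromo alone. The compounds also leave open whether the gap between bromo and the other two groups would persist if the rest of the shared core changed, for example with a longer chain on the amide carbonyl.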